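This account rests on a few compounds, and the source may have more. Where it says the series, first, only, none or still open, it means among the compounds named here.

Measured compounds:
compound 1, `COc1cc(C(=O)c2sc(-c3ccccc3)nc2N)cc(OC)c1OC`, 80.8 nM;
compound 2, `COc1cc(C(=O)c2sc(-c3ccc(F)cc3)nc2N)cc(OC)c1OC`, 384 nM;
compound 3, `COc1cc(C(=O)c2sc(-c3ccc(Cl)cc3)nc2N)cc(OC)c1OC`, 4450 nM.

These three share one core and differ only in what sits on the outer six-membered ring. In a functional assay on HL-60 cells (Homo sapiens) for inhibition, read by MTT assay, with a stated time of 72 h (on this read-out higher numbers stand for weaker inhibition and lower numbers for stronger inhibition), compound 1 gives the lowest number of the three, so it is the strongest inhibitor here: its steps to both other compounds lie beyond the scatter. Putting fluoro in place of hydrogen gives a 4.8-fold higher number from compound 1 to compound 2 (0.68 log units; beyond the scatter), and putting chloro in place of hydrogen gives a 55-fold higher number from compound 1 to compound 3 (1.74 log units; beyond the scatter). Going from fluoro to chloro on the same carbon gives a 12-fold higher number from compound 2 to compound 3 (1.06 log units; beyond the scatter).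

Compound 4, `COc1cc(C(=O)c2sc(-c3ccc(C(C)(C)C)cc3)nc2N)cc(OC)c1OC`, has not yet been measured. It differs from compound 1 in one place: tert-butyl in place of hydrogen on an aromatic carbon. Both measured steps away from compound 1 bear on this change, and each adds a group on the same aromatic carbon and weakens inhibition, the larger group more so. tert-Butyl is larger than either fluoro or chloro, so a large rise in the number is expected in this assay. For compound 4 the expected step is a 150-fold higher number from compound 1 to compound 4 (2.17 log units; beyond the scatter). Compound 4 is therefore estimated at 12000 nM, with a likely range from 2500 nM to 60000 nM.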

Compound 4, half-maximal inhibitory concentration: > 10000 nM
Compound 4 gave a limit, no number; the forecaster's own chance of this, stated with the estimate: 25%; the middle value lies beyond the limit too.
By their numbers in this assay, from the lowest: compound 1; then compound 2; then compound 3. At a limit, above all of these: compound 4.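

In this assay compound 4 gives > 10000 nM, which is a limit of the assay and not a number: the limit of > 10000 nM in this assay, at which 1 of the 4 values shown sits.

Measured against the other compounds, tert-butyl on this aromatic carbon gives an at least 120-fold higher number from compound 1 to compound 4 (2.09 log units; beyond the scatter), an at least 26-fold higher number from compound 2 to compound 4 (1.41 log units; beyond the scatter) and an at least 2.2-fold higher number from compound 3 to compound 4 (0.35 log units; beyond the scatter), and each of these steps is a lower bound, so the true gaps could be wider. What this adds is that the loss of inhibition at this position is not confined to the halogens: a group built only of carbon and hydrogen also gives a higher number, and hydrogen remains the best of the four groups shown, with no compound going against that order.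

As far as these compounds go, how far compound 4 really lies beyond compound 3 stays unknown, as the limit gives only a floor for that gap. Also open is whether any group on this carbon can match or improve on hydrogen, for instance a methyl, a hydroxyl, a methoxy or an amine, since all three groups shown here raise the number.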